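The compounds below may be only part of what the source reports. "The series", "measured", "known", "first", "only" and "open" are said of these compounds alone.

Working notes on the series, read in a physicochemical assay for solubility, read by HPLC, in phosphate buffer, with a stated time of 24 h, at pH 7.4, tested at 100 uM; on this read-out higher numbers stand for higher solubility and lower numbers for lower solubility. Compound 1 (`O=C(CCCCCCNc1c(Nc2ccccc2)c(=O)c1=O)NO`) gives 6000000 nM, compound 2 (`O=C(CCCCCNc1c(Nc2ccccc2)c(=O)c1=O)NO`) gives 47000000 nM and compound 3 (`O=C(CCCCNc1c(Nc2ccccc2)c(=O)c1=O)NO`) gives 87000000 nM. Compound 2 stands with compound 3, at a 1.9-fold higher number from compound 2 to compound 3 (0.27 log units; within the scatter), and apart from compound 1, at a 7.8-fold higher number from compound 1 to compound 2 (0.89 log units; beyond the scatter). The third measured step, a 15-fold higher number from compound 1 to compound 3 (1.16 log units; beyond the scatter), is also a change of chain length.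

Compound 4 (`O=C(CCCCCNc1c(NC2CCCCC2)c(=O)c1=O)NO`) keeps the chain of compound 2 and changes the other end: cyclohexyl in place of phenyl on a nitrogen on an aromatic ring. All three measured steps concern the chain, and none touches this group, so the series gives no direct measure of this change. The expectation in this assay is no step beyond the scatter, in either direction, with a wide range to reflect the missing evidence. Compound 4 is expected at 45000000 nM, within an estimated range of 15000000 nM to 100000000 nM. The estimated step is a 1.0-fold lower number from compound 2 to compound 4 (0.02 log units; within the scatter).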

Compound 4, solubility: 91000000 nM
Compound 4: middle estimate off by 2.0-fold (0.31 log units), on the low side; the measured number falls inside the stated range.
By their numbers in this assay, from the lowest: compound 1; then compounds 2, 3 and 4 (each within the scatter of the next).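

With the chain of compound 2 held fixed, the other end of the molecule now has a direct reading in this assay: cyclohexyl in place of phenyl on a nitrogen on an aromatic ring gives a 1.9-fold higher number from compound 2 to compound 4 (0.29 log units; within the scatter) and so does not separate the aromatic ring from the non-aromatic ring on this read-out. At this chain length, the change at this position stays within the scatter, whereas shortening the chain gives a 7.8-fold higher number from compound 1 to compound 2 (0.89 log units; beyond the scatter) in the series. No measured property on hand accounts for this reading.

On these data alone, whether the same exchange would read alike on the longer chain of compound 1 stays open. Also open, as far as these compounds go, is how a pyridyl or morpholinyl group on this nitrogen, or a carboxylic acid in place of the hydroxycarbamoyl group, would read.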